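Chain Amine Swap on a Flavone Series in HepG2 Cells

This account rests on a few compounds, and the source may have more. Where it says the series, first, only, none or still open, it means among the compounds named here.

Three flavone analogues have been measured in a functional assay on HepG2 cells (Homo sapiens) for antiproliferative activity, read by MTT assay, with a stated time of 48 h (on this read-out lower numbers stand for stronger inhibition and higher numbers for weaker inhibition), and a fourth awaits its value. Compound 1 `COc1cc2oc(-c3ccccc3)cc(=O)c2c(O)c1OCCCCN1CCN(C)CC1` gives 36700 nM in this assay. Compound 2 `CCN(CC)CCCCOc1c(OC)cc2oc(-c3ccccc3)cc(=O)c2c1O` gives 7100 nM, and compound 3 `COc1cc2oc(-c3ccccc3)cc(=O)c2c(O)c1OCCCN1CCN(C)CC1` gives 15100 nM. Compound 4 `CCN(CC)CCCOc1c(OC)cc2oc(-c3ccccc3)cc(=O)c2c1O` has not yet been measured.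

The difference between compound 1 and compound 2 is diethylamino in place of 4-methylpiperazin-1-yl on a saturated chain carbon, four bonds along the chain from an oxygen on an aromatic ring, and that step produced a 5.2-fold lower number from compound 1 to compound 2 (0.71 log units; beyond the scatter). The cores of compound 1 and compound 3 differ by 4-methylpiperazin-1-yl in place of (4-methylpiperazin-1-yl)methyl on a saturated chain carbon, three bonds along the chain from an oxygen on an aromatic ring, a step of a 2.4-fold lower number from compound 1 to compound 3 (0.39 log units; beyond the scatter). Compound 4 differs from compound 3 by diethylamino in place of 4-methylpiperazin-1-yl on a saturated chain carbon, three bonds along the chain from an oxygen on an aromatic ring, the same kind of change as in the earlier pair, though here it sits three bonds along the chain from the aromatic oxygen rather than four. Between compound 2 and compound 3 the step was a 2.1-fold higher number from compound 2 to compound 3 (0.33 log units; beyond the scatter).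

Compound 4 is expected to show a step of about a 5.0-fold lower number from compound 3 to compound 4 (0.70 log units; beyond the scatter), resting on the earlier step of a 5.2-fold lower number from compound 1 to compound 2 (0.71 log units; beyond the scatter) in this assay. On that basis compound 4 is estimated at 3000 nM, within a range from 1200 nM to 7500 nM.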

Compound 4, half-maximal inhibitory concentration: 3700 nM
Compound 4: middle estimate off by 1.2-fold (0.09 log units), on the low side; low and high end bracket the measured number.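

In this assay, diethylamino in place of 4-methylpiperazin-1-yl gave a 4.1-fold lower number from compound 3 to compound 4 (0.61 log units; beyond the scatter), and the change kept much the same size whether it sat four or three bonds along the chain from the aromatic oxygen: the same change on two cores in this assay, a 5.2-fold lower number (0.71 log units; beyond the scatter) from compound 1 to compound 2 and a 4.1-fold lower number (0.61 log units; beyond the scatter) from compound 3 to compound 4, 1.3-fold (0.10 log units) apart, within the scatter of two such steps. Chain length alone gives no order within the diethylamino pair, as the step of a 1.9-fold lower number from compound 2 to compound 4 (0.28 log units; within the scatter) shows, while the amine swap and the chain difference together span a 9.9-fold lower number from compound 1 to compound 4 (1.00 log units; beyond the scatter). Within the data shown here, this agreement rests on only two pairs that differ in chain length, so it shows the change carrying over between these two cores and says nothing about how it would behave on any other.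

The compounds shown leave open whether the same step would appear with other amines, such as morpholine or pyrrolidine, or with a longer chain. They offer no read-out other than this one, so the reason for the step remains unknown.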